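The source may report more compounds than this note shows. Statements on the series, on what has been measured and on what is new or still open speak of the compounds shown alone.

For the measured compounds named here, compound 2 `COc1ncc(-c2ccc3nccc(-c4ccc(CN5CCN(C)CC5)cc4)c3c2)cc1NS(=O)(=O)c1ccc(F)cc1F` gives 43.9 nM in a functional assay on HCT-116 cells (Homo sapiens) for cytotoxicity, read by MTT assay, with a stated time of 72 h (a lower number here means a stronger inhibitor, a higher number a weaker inhibitor), the highest of the two numbers so far; the only other compound, compound 1 `COc1ncc(-c2ccc3nccc(-c4ccc(CN5CCCCC5)cc4)c3c2)cc1NS(=O)(=O)c1ccc(F)cc1F`, gives 34.1 nM. Going by the values given here, the one measured step, a 1.3-fold higher number from compound 1 to compound 2 (0.11 log units; within the scatter), stays within the scatter. Compound 3 `COc1ncc(-c2ccc3nccc(-c4ccc(Cn5cncn5)cc4)c3c2)cc1NS(=O)(=O)c1ccc(F)cc1F` differs from compound 2 by 1H-1,2,4-triazol-1-yl in place of 4-methylpiperazin-1-yl on a saturated chain carbon bound to an aromatic carbon. Among the compounds with values here, no measured step exchanges one of these groups for an aromatic ring, so the earlier step bears on this change only loosely. The expectation is a modest rise, with the step of a 1.5-fold higher number from compound 2 to compound 3 (0.17 log units; within the scatter). Compound 3 is therefore estimated at 65 nM, with a range from 20 nM to 210 nM.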

Compound 3, half-maximal inhibitory concentration: 8.7 nM
For compound 3 the middle estimate is 7.5-fold (0.87 log units) above the measured one, and the stated range ends above it.
By their numbers in this assay, from the lowest: compound 3; then compounds 1 and 2 (each within the scatter of the next).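

In this assay, the group on a saturated chain carbon bound to an aromatic carbon now clearly matters: 1H-1,2,4-triazol-1-yl in place of the saturated rings gives a 5.0-fold lower number from compound 2 to compound 3 (0.70 log units; beyond the scatter) and a 3.9-fold lower number from compound 1 to compound 3 (0.59 log units; beyond the scatter) and so compound 3 has the lowest number of the three. The earlier exchange of one saturated ring for another showed no such separation. Nothing available here accounts for this drop.

From the compounds shown here alone, whether it needs this particular ring remains open, since a pyrazol-1-yl or imidazol-1-yl group could show whether all three ring nitrogens count. A longer chain carrying the triazole is equally untested among these compounds.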